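Removing a Methyl Group from a Phenol Ether

The source may hold more compounds than are shown below. What is called first, only, known or untested is meant among the compounds shown, and "the series" means these compounds.

Of the compounds shown here, three built on one shared core have been tested in a functional assay on OVCAR-4 cells (Homo sapiens) for inhibition, read by sulforhodamine B assay, with a stated time of 48 h; on this read-out lower numbers stand for higher toxicity in this test and higher numbers for lower toxicity in this test. Compound 1 `O=C(Nc1cccc(-n2cc(-c3ccncc3)c(-c3ccc(Cl)c(O)c3)n2)c1)Nc1cccc(C(F)(F)F)c1` gives > 32500 nM, which is a limit of the assay rather than a number. Compound 2 `COc1cc(-c2nn(-c3cccc(NC(=O)Nc4cc(C(F)(F)F)cc(C(F)(F)F)c4)c3)cc2-c2ccncc2)ccc1Cl` gives > 50000 nM, again a limit. Compound 3 `COc1cc(-c2nn(-c3cccc(NC(=O)Nc4cccc(C(F)(F)F)c4)c3)cc2-c2ccncc2)ccc1Cl` gives > 50000 nM, also a limit. So compound 2 stands at a limit, and the two other values shown are limits as well.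

Compound 4 `O=C(Nc1cccc(-n2cc(-c3ccncc3)c(-c3ccc(Cl)c(O)c3)n2)c1)Nc1cc(C(F)(F)F)cc(C(F)(F)F)c1` has not yet been measured. It differs from compound 2 by hydrogen in place of methyl on an oxygen on an aromatic ring. The closest measured step is a step that the two limits leave unreadable from compound 1 to compound 3, the same change run the other way, and it cannot be sized because compound 1 sits at the limit of > 32500 nM in this assay, at which 1 of the 3 values shown sits, while compound 3 sits at the limit of > 50000 nM in this assay, at which 2 of the 3 values shown sit. The other step, a step that the two limits leave unreadable from compound 2 to compound 3, touches a different place and is unreadable for the same reason. Nothing measured here therefore shows that taking the methyl off the oxygen moves this read-out out of the scatter.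

Compound 4 is thus expected to stay at a limit in this assay, with the step of a number no higher from compound 2 to compound 4 (the limit leaves the size open) estimated as none beyond the scatter. The estimate for compound 4 is 50000 nM, within 20000 nM to 100000 nM.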

Compound 4, concentration lethal to 50% of the cells: 23900 nM
The estimate for compound 4 lay 2.1-fold (0.32 log units) above the measured number, within the range that was stated.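

In this assay, the methoxy to hydroxy change on the oxygen of the aromatic ring now has a visible effect, with an at least 2.0-fold lower number from compound 2 to compound 4 (0.32 log units; beyond the scatter), so a free hydroxy can go with higher toxicity in this test when the other end of the molecule carries two trifluoromethyl groups. The second trifluoromethyl group is less clearly tied to the result, since the step with hydroxy in place on both sides is an at least 1.3-fold lower number from compound 1 to compound 4 (0.13 log units; that floor lies within the scatter), and a floor of that size does not establish a real difference. Compound 2 stands at a limit of the assay, so the first step has a floor but no upper size: the limit of > 50000 nM in this assay, at which 2 of the 4 values shown sit.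

The steps from compound 1 to compound 3 and from compound 2 to compound 3 cannot be read, which leaves it unclear whether the hydroxy alone accounts for the lower number or needs both trifluoromethyl groups alongside it. Also open, on these data alone, is how an amine or a carboxylic acid in place of the hydroxy on this ring would behave in this assay.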